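The source may hold more compounds than are shown below. What is called first, only, known or untested is meant among the compounds shown, and "the series" means these compounds.

Measured in a functional assay on U-251 cells (Homo sapiens) for inhibition, read by MTT assay, with a stated time of 2 days; a lower number here means a stronger inhibitor of growth, a higher number a weaker inhibitor of growth:
compound 1 `Nc1ccccc1NC(=O)CCCNCC(=O)Nc1cccc(Cl)c1`: > 100000 nM (a limit)
compound 2 `Nc1ccccc1NC(=O)CCCNCC(=O)Nc1ccc(Cl)cc1`: 75000 nM

Compound 1 has no number of its own. It sits at the limit of > 100000 nM in this assay, at which 1 of the 2 values shown sits. The unmeasured compound 3 `Nc1ccccc1NC(=O)CCCNCC(=O)Nc1ccc(Br)cc1` keeps the core of compound 1 and differs from it as follows: 4-bromophenyl in place of 3-chlorophenyl on an amide-type nitrogen. In words, it has 4-bromophenyl in place of 3-chlorophenyl on an amide-type nitrogen.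

Going by the values given here, one measured step bears on this change: an at least 1.3-fold lower number from compound 1 to compound 2 (0.12 log units; that floor lies within the scatter). That step puts 4-chlorophenyl in place of 3-chlorophenyl at the same place. It is only a floor, and that floor lies within the scatter, so it gives weak guidance on size and direction. Among the compounds with values here, the expectation for compound 3 therefore leans on compound 2 at 75000 nM, the only real number available.

A small move towards a lower number is expected, possibly no more than the scatter, and the estimated change is an at least 1.4-fold lower number from compound 1 to compound 3 (0.15 log units; that floor lies within the scatter). For compound 3 the estimate is 70000 nM, with an expected range of 35000 nM to 120000 nM.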

Compound 3, concentration for total growth inhibition: 80000 nM
Estimate against measurement, compound 3: 1.1-fold (0.06 log units) below, within the range that was stated.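

In this assay, the change from chloro to bromo on an aromatic carbon gives a 1.1-fold higher number from compound 2 to compound 3 (0.03 log units; within the scatter), so compound 2 and compound 3 cannot be told apart and this exchange of halogen has no readable effect at this place. This adds a second compound with a 4-halophenyl group on the amide-type nitrogen that gives a real number, whereas the only 3-substituted compound shown, compound 1, does not. The change from 3-chlorophenyl to 4-bromophenyl gives an at least 1.2-fold lower number from compound 1 to compound 3 (0.09 log units; that floor lies within the scatter), and this floor cannot show whether moving the halogen matters, as compound 1 has only a limit of the assay and no number of its own: the limit of > 100000 nM in this assay, at which 1 of the 3 values shown sits.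

The compounds shown leave open whether anything other than a halogen on the phenyl ring, such as an amine or a carboxylic acid, would shift the number beyond the scatter. They also leave open how 3-bromophenyl would compare with 3-chlorophenyl at this place, and what a longer chain in the shared core would do.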